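Bromo for Methyl on the Sulfinyl Aryl Ring: Cytotoxicity

The source may report more compounds than this note shows. Statements on the series, on what has been measured and on what is new or still open speak of the compounds shown alone.

Compound 1 `Cc1ccccc1[S+]([O-])c1cccc(N)c1C#N`: in a functional assay on MT4 cells (Homo sapiens) for cytotoxicity (a higher number here means a weaker inhibitor, a lower number a stronger inhibitor), compound 1 reaches only the limit > 200000 nM.
Compound 2 `Cc1ccc([S+]([O-])c2cccc(N)c2C#N)cc1`: in this assay compound 2 likewise reaches only the limit > 200000 nM.
Compound 3 `N#Cc1c(N)cccc1[S+]([O-])c1ccccc1Br`: in this assay compound 3 gives 168000 nM.

Compound 3 differs from compound 1 by bromo in place of methyl on an aromatic carbon, and this gave an at least 1.1-fold lower number from compound 1 to compound 3 (0.07 log units; that floor lies within the scatter), a step that starts from a limit, as the limit of > 200000 nM in this assay, at which 2 of the 3 values shown sit, shows. The difference between the cores of compound 1 and compound 2 is not broken down here. Compound 4 `N#Cc1c(N)cccc1[S+]([O-])c1ccc(Br)cc1` differs from compound 2 by bromo in place of methyl on an aromatic carbon; the place differs, para to a large group rather than ortho to a large group, so this is the same kind of change. Given the step from compound 1 to compound 3, compound 4 is expected to move from compound 2 by about a number no higher from compound 2 to compound 4 (the limit leaves the size open). Compound 4 is therefore estimated at 200000 nM, between 120000 nM and 400000 nM, with a real chance that only a limit is reported.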

Compound 4, half-maximal inhibitory concentration: > 200000 nM
Compound 4: a limit, no number; the forecaster's own chance of this, stated with the estimate: 55%; the middle value lies on the limit itself.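

Compound 2 and compound 4 both stand only as limits in this assay, so no step can be read between them: the limit of > 200000 nM in this assay, at which 3 of the 4 values shown sit.
The compounds shown leave open whether bromo in place of methyl on an aromatic carbon changes the number at all.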